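The source may hold more compounds than are shown below. What is called first, only, known or untested is meant among the compounds shown, and "the series" means these compounds.

Measured so far:
compound 1 `CCOc1cc(CN2CCC(NC(=O)c3ccc(NC)nc3)CC2)cc(OCC)c1F`: 2.66
compound 2 `CCOc1cc(CN2CCC(NC(=O)c3cncc(C)c3)CC2)cc(OCC)c1Cl`: 3.43

In a physicochemical assay for lipophilicity, read by spectrophotometry, measured as octanol-water partition, at pH 7.4 (a higher number here means a more lipophilic compound, a lower number a more polar compound), compound 1 is the lower of the two at 2.66, with compound 2 higher by more than the scatter. Compound 3 `CCOc1cc(CN2CCC(NC(=O)c3ccc(NC)nc3)CC2)cc(OCC)c1-c1ccc(F)cc1` is still unmeasured. It departs from compound 1 in one place: 4-fluorophenyl in place of fluoro on an aromatic carbon, with 4-fluorophenyl in place of fluoro on an aromatic carbon. For the measured compounds named here, no measured pair shows a change at this place, so the expectation rests on the structural change alone. An upward move beyond the scatter is expected, with an estimated step of a number 1.34 log units higher from compound 1 to compound 3 (beyond the scatter). Compound 3 is estimated at 4, with an expected range of 3.5 to 4.5.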

Compound 3, distribution coefficient: 3.83
Estimate against measurement, compound 3: 0.17 log units above, and the stated range covers the measured number.
By their numbers in this assay, from the lowest: compound 1; then compound 2; then compound 3.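

For the compounds shown here, with 4-fluorophenyl in place of fluoro on the aromatic carbon, this assay gives a number 1.17 log units higher from compound 1 to compound 3 (beyond the scatter), the only step read so far at this position. The position therefore tolerates no silent exchange: a group bringing one six-membered aromatic ring of carbon only, and no hydrogen-bond donors or acceptors, moves the number by a large step. Nothing measured accounts for the size of that step. The compounds shown leave open how an unsubstituted phenyl, an amine or a carboxylic acid would read at this carbon. As far as these compounds go, whether the step holds with a different amide portion also remains open.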